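Acylating the aminomethyl amine of compound 2

This account rests on a few compounds, and the source may have more. Where it says the series, first, only, none or still open, it means among the compounds named here.

Measured in a functional assay on CCRF-CEM cells (Homo sapiens) for inhibition; a higher number here means a weaker inhibitor, a lower number a stronger inhibitor:
- compound 1 `Cc1cccc(-c2cnc(Nc3ccc4c(C#N)cn(C)c4c3)o2)c1`: > 10000 nM
- compound 2 `Cn1cc(C#N)c2ccc(Nc3ncc(-c4ccc(CN)cc4)o3)cc21`: 2800 nM
- compound 3 `Cn1cc(C#N)c2ccc(Nc3ncc(-c4cccc(NC(=O)c5ccccc5)c4)o3)cc21`: 3500 nM

The entry of compound 1, > 10000 nM, is a limit of the assay and not a number. Within the data shown here, only two true numbers are therefore available: compound 2 gives 2800 nM and compound 3 gives 3500 nM, and these lie within the usual scatter of each other.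

The next comparison is with compound 4 `Cn1cc(C#N)c2ccc(Nc3ncc(-c4ccc(CNC(=O)C(C)(C)C)cc4)o3)cc21`, which carries (tert-butyl)carbonyl in place of hydrogen on an amine nitrogen of compound 2: (tert-butyl)carbonyl in place of hydrogen on an amine nitrogen.

Two measured steps are relevant, though both start from the limit and so give only bounds: an at least 3.5-fold lower number from compound 1 to compound 2 (0.55 log units; beyond the scatter), and an at least 2.8-fold lower number from compound 1 to compound 3 (0.45 log units; beyond the scatter). Neither step changes the amine nitrogen itself, so the size of this change is not directly measured. The closest guide is compound 3, which holds a benzamido group and still gives 3500 nM. An amide in compound 4 is therefore not expected to move the number far, and any shift is expected to be upward if it occurs. The expected step is a 1.4-fold higher number from compound 2 to compound 4 (0.15 log units; within the scatter), with no change beyond the scatter as the likeliest outcome. The estimated value for compound 4 is 4000 nM, expected to fall between 1500 nM and 10000 nM.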

Compound 4, half-maximal inhibitory concentration: 4900 nM
Compound 4: the middle estimate sits 1.2-fold (0.09 log units) below what was measured; measured number inside the range.
By their numbers in this assay, from the lowest: compounds 2, 3 and 4 (each within the scatter of the next). At a limit, above all of these: compound 1.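

In this assay, the first change shown on the amine nitrogen of the aminomethyl group gives a 1.8-fold higher number from compound 2 to compound 4 (0.24 log units; within the scatter), so this change produces no readable shift in the number. On this evidence, the free amine of compound 2 is not required to keep a true number in this assay: (tert-butyl)carbonyl, with its 6 heavy atoms and no hydrogen-bond donor of its own, can replace a hydrogen on that nitrogen without a step beyond the scatter. Compound 1 remains the only entry that is a limit and not a number: the limit of > 10000 nM in this assay, at which 1 of the 4 values shown sits.

As far as these compounds go, whether a different group on this nitrogen, such as a small acetyl, a methyl or a benzoyl, would move the number beyond the scatter remains open, as does the effect of replacing the aminomethyl group with a carboxylic acid. Compound 3 and compound 4 differ in more than one place, so the placement of the amide on the outer phenyl ring cannot be separated from the other differences between them.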